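This account rests on a few compounds, and the source may have more. Where it says the series, first, only, none or still open, it means among the compounds named here.

Of the compounds shown here, three on the shared core have been read in an ADME assay on Akata cells (Homo sapiens) for cytotoxicity, with a stated time of 7 days; a lower number here means that less compound is tolerated, a higher number that more compound is tolerated: compound 1 (`Nc1nc(OCC(F)(F)F)c2ncn(/C=C3/CC3(CO)CO)c2n1`), compound 2 (`Nc1nc(NC2CCCC2)c2ncn(/C=C3/CC3(CO)CO)c2n1`) and compound 3 (`CCCCCCSc1nc(N)nc2c1ncn2/C=C1/CC1(CO)CO`). Compound 1 gives > 20000 nM as a limit of the assay. Compound 2 gives > 20000 nM as a limit too. Compound 3 gives > 20000 nM as a limit as well, so in this assay it holds no number of its own. All three sit together (the limit of > 20000 nM in this assay, at which 3 of the 3 values shown sit).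

The change from compound 3 to compound 4 (`CC(C)Sc1nc(N)nc2c1ncn2/C=C1/CC1(CO)CO`) is isopropyl in place of hexyl on a sulfur. The nearest measured steps are a step that the two limits leave unreadable from compound 1 to compound 3 and a step that the two limits leave unreadable from compound 2 to compound 3 with a step that the two limits leave unreadable from compound 1 to compound 2 behind them. Among the compounds with values here, none of these gives a size to carry over, and no measured step changes the chain on the sulfur alone.

No step beyond the scatter is therefore expected in this assay, and no direction is expected either. This expectation rests on compound 3 and its limit of > 20000 nM as the only starting point. The expected step is a number no higher from compound 3 to compound 4 (the limit leaves the size open) on this reading. For compound 4 the estimate is 20000 nM with an expected range from 10000 nM to 40000 nM and a report as a limit is the likeliest outcome.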

Compound 4, half-maximal cytotoxic concentration: > 20000 nM
Compound 4: only a limit was reported; the forecaster's own chance of this, stated with the estimate: 85%; the middle value sits exactly at the limit.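

Compound 4 joins compound 1, compound 2 and compound 3 as a limit in this assay, so no step from any of them to compound 4 can be read: the limit of > 20000 nM in this assay, at which 4 of the 4 values shown sit.

The compounds shown leave open where any of them would give a number of its own in this assay, and whether the chain on the sulfur changes that number.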